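Amide nitrogen substituent in the shared core

A few compounds are considered here, and "the series" means these few. Any claim that something is new, unique, unknown or untested is made for them only; others in the source may bear on it.

Of the compounds shown here, three have been read in an assay on isolated protein for inhibition of Apoptosis regulator Bcl-2 (Homo sapiens), read by fluorescence polarization, with stated times of 5 min and 10 min; on this read-out lower numbers stand for stronger inhibition and higher numbers for weaker inhibition. Compound 1 `CC(C)=CCCC1=CC[C@H](C(=O)NCCC(=O)O)[C@@H](c2ccccc2)C1` gives in this assay only a limit, > 23000 nM. Compound 2 `COc1ccc(NC(=O)[C@H]2CC=C(CCC=C(C)C)C[C@@H]2c2ccccc2)cc1` gives in this assay likewise only a limit, > 23000 nM. Compound 3 `COc1ccc(NC(=O)[C@@H]2CC=C(CCC=C(C)C)C[C@H]2c2ccccc2)cc1` gives in this assay only a limit as well, > 23000 nM. Both steps within the measured set, a step that the two limits leave unreadable from compound 1 to compound 2 and a step that the two limits leave unreadable from compound 2 to compound 3, are therefore unreadable in size and direction, which follows from the limit of > 23000 nM in this assay, at which 3 of the 3 values shown sit; the second of them rests only on (the fact that compounds 2 and 3 differ only in the configuration as drawn).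

Compound 4 `CC(C)=CCCC1=CC[C@@H](C(N)=O)[C@H](c2ccccc2)C1` differs from compound 3 by hydrogen in place of 4-methoxyphenyl on an amide-type nitrogen. Among the compounds with values here, no measured step bears on that change with a readable size, so nothing from the measured steps carries over, and the standing of compound 3 at a limit gives the only anchor. On that basis compound 4 is expected to remain at or near the same limit, with a modest chance of a readable number. Compound 4 is estimated at 30000 nM, within 10000 nM and 100000 nM. That estimate means an expected step that the limit leaves unreadable from compound 3 to compound 4, within the scatter of this assay.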

Compound 4, inhibition constant: > 23000 nM
Compound 4 ended at the assay's limit; the forecaster's own chance of this, stated with the estimate: 80%; the middle value does not contradict the limit.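

In this assay compound 4 gives > 23000 nM, which is a limit and not a number. The step between compound 3 and compound 4 therefore cannot be read. The compounds shown leave open whether any amide nitrogen substituent on the shared core gives a readable inhibition constant.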